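Removing chloro from a non-toxic pair: compound 3

The source may hold more compounds than are shown below. What is called first, only, known or untested is meant among the compounds shown, and "the series" means these compounds.

Compound 1: `O=C(O)c1cccc(-c2ccc(/C=C3\S/C(=N\c4ccccc4)N(c4ccc(F)cc4)C3=O)o2)c1` — in an ADME assay on Vero cells (Chlorocebus sabaeus) for cytotoxicity (on this read-out higher numbers stand for lower toxicity in this test and lower numbers for higher toxicity in this test), compound 1 gives > 200000 nM, a limit of the test.
Compound 2: `O=C(O)c1cccc(-c2ccc(/C=C3\S/C(=N\c4ccc(Cl)cc4)N(c4ncccc4F)C3=O)o2)c1` — in this assay compound 2 gives > 200000 nM, likewise a limit.

Compound 2 therefore stands at the same place as compound 1 on the numbers shown: both sit at the limit of > 200000 nM in this assay, at which 2 of the 2 values shown sit, so neither gives a number, only a ceiling below which no cytotoxic concentration was found. Compound 3, `O=C(O)c1cccc(-c2ccc(/C=C3\S/C(=N\c4ccccc4)N(c4ncccc4F)C3=O)o2)c1`, has yet to be measured in this assay. It differs from compound 2 by hydrogen in place of chloro on an aromatic carbon; cut one bond further out, this reads 4-chlorophenyl to phenyl. For the measured compounds named here, no measured step ties this change to the read-out. Since compound 1, which carries the phenyl, and compound 2, which carries the 4-chlorophenyl, both sit at the limit, compound 3 is expected to show a step that the limit leaves unreadable from compound 2 to compound 3, none beyond the scatter. Compound 3 is estimated at 250000 nM, between 150000 nM and 450000 nM.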

Compound 3, half-maximal cytotoxic concentration: > 200000 nM
Compound 3 ended at the assay's limit; the forecaster's own chance of this, stated with the estimate: 85%; the middle value is on the limit's open side.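

In this assay, the steps linking compound 3 to compound 1 and compound 2 cannot be read, as all three compounds sit at one limit: the limit of > 200000 nM in this assay, at which 3 of the 3 values shown sit. The compounds shown leave open whether swapping chloro for hydrogen, or 4-fluorophenyl for 3-fluoropyridin-2-yl, changes the read-out beyond that limit.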